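Aryl exchange on the saturated ring carbon

The compounds below may be only part of what the source reports. "The series", "measured", "known", "first", "only" and "open" are said of these compounds alone.

Compound 1 `CC1=C(C(=O)Nc2ccc(F)cc2)C(c2ccc(Cl)cc2)n2c(s/c(=C/c3ccccc3Cl)c2=O)=N1` and compound 2 `CC1=C(C(=O)Nc2ccc(F)cc2)C(c2ccccc2[N+](=O)[O-])n2c(s/c(=C/c3ccccc3Cl)c2=O)=N1` share one core and differ only in the aryl group on a saturated ring carbon. In a functional assay on the whole organism (strain albino) for inhibition, with Rattus norvegicus as the target, read by paw edema, with stated times of 1 h and 3 h, at a dose of 25 mg/kg by the oral route (on this read-out lower numbers stand for less inhibition and higher numbers for more inhibition at the one dose given (going by the name of the read-out)), compound 1 gives 16%, and compound 2 gives 12%. Of the two numbers shown, that of compound 2 is the one nearer the bottom, but the step of a number 4 percentage points lower from compound 1 to compound 2 (within the scatter) lies within the scatter. Compound 3 `CC1=C(C(=O)Nc2ccc(F)cc2)C(c2ccc(F)cc2)n2c(s/c(=C/c3ccccc3Cl)c2=O)=N1` carries the change (4-fluorophenyl in place of 2-nitrophenyl on a saturated ring carbon). Among the measured compounds shown here, the only measured step that bears on this aryl exchange is that small one, so no shift beyond the scatter is expected in this assay. Compound 3 is estimated at 15%, range 7% to 24%, an expected step of a number 3 percentage points higher from compound 2 to compound 3 (within the scatter).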

Compound 3, a percentage reported as inhibition, in the whole organism at one dose (the size of the read-out at that dose, not a potency): 19%
The estimate for compound 3 lay 4 percentage points below the measured number; the measured number falls inside the stated range.
By their numbers in this assay, from the lowest: compounds 2, 1 and 3 (each within the scatter of the next).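

In this assay the exchange of 2-nitrophenyl for 4-fluorophenyl on the saturated ring carbon gives a number 7 percentage points higher from compound 2 to compound 3 (within the scatter) and the swap of fluoro in place of chloro on an aromatic carbon gives a number 3 percentage points higher from compound 1 to compound 3 (within the scatter) in the same series. All three aryl groups on this carbon now stand within the scatter of one another at the one dose given, so neither change separates the compounds. No measurement on hand gives a reason for these small steps. As far as these compounds go, it remains open whether an aminophenyl or a carboxyphenyl group on this carbon would move the number beyond the scatter. From the compounds shown here alone, a saturated alkyl chain in place of the aryl ring is equally open.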